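This account rests on a few compounds, and the source may have more. Where it says the series, first, only, none or still open, it means among the compounds named here.

Measured in a functional assay with Alpha-1A adrenergic receptor (Homo sapiens) as the target, read by calcium flux; on this read-out lower numbers stand for smaller maximal responses and higher numbers for larger maximal responses:
compound 1 `c1cncc(-c2ccccc2OCC2=NCCN2)c1` — 109%
compound 2 `c1ccc(-c2ccns2)c(OCC2=NCCN2)c1` — 99%

Compound 2 sits alongside compound 1, with a number 10 percentage points lower from compound 1 to compound 2 (within the scatter), so the two are within the scatter of each other. Compound 3 `Cc1ccc(-c2ccccc2OCC2=NCCN2)s1` differs from compound 2 by 5-methylthiophen-2-yl in place of 1,2-thiazol-5-yl on an aromatic carbon. Among the measured compounds shown here, only the step from compound 1 to compound 2 bears on this, and it is within the scatter; exchanging one five-membered heteroaryl for another is therefore expected to leave the maximum largely unchanged, and a number 1 percentage points higher from compound 2 to compound 3 (within the scatter) is the expected step. For compound 3 the estimate in this assay is 100%, within 85% to 115%.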

Compound 3, largest response reached (reported as maximum), in percent of the reference or control that the assay uses: 97%
Compound 3: middle estimate off by 3 percentage points, on the high side; the range from low to high includes it.
By their numbers in this assay, from the lowest: compounds 3, 2 and 1 (each within the scatter of the next, the first and the last beyond it).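

In this assay, 5-methylthiophen-2-yl in place of 1,2-thiazol-5-yl gives a number 2 percentage points lower from compound 2 to compound 3 (within the scatter), so this position accepts a ring with one hetero atom and a methyl group without a change that can be read. Among the compounds shown here, the same group in place of pyridin-3-yl gives a number 12 percentage points lower from compound 1 to compound 3 (beyond the scatter), the first step beyond the scatter, though a modest one. No evidence on hand accounts for this step.

From the compounds shown here alone, the separate contributions of the methyl group and the ring hetero atoms remain open. So does the response to a carboxylic acid or an aminomethyl group at this place.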